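Dimethoxyphenyl in Place of Phenyl on Compound 1

The compounds below may be only part of what the source reports. "The series", "measured", "known", "first", "only" and "open" are said of these compounds alone.

Compound 1 `COc1cc(/C=C/C(=O)/C=C/c2ccccc2)ccc1OCc1cn(CCCOc2cc(=O)oc3ccccc23)nn1` stands highest of the three compounds measured in a functional assay on COLO 205 cells (Homo sapiens) for inhibition, read by sulforhodamine B assay, with a stated time of 48 h, tested at 50 uM (a lower number here means less inhibition of growth, a higher number more inhibition of growth at the concentration tested), where compound 1 gives 43%. Compound 2 `COc1ccccc1/C=C/C(=O)/C=C/c1ccc(OCc2cn(CCCCCOc3cc(=O)oc4ccccc34)nn2)c(OC)c1` gives 30%, and compound 3 `COc1cc(/C=C/C(=O)/C=C/c2cccs2)ccc1OCc1cn(CCCCCOc2cc(=O)oc3ccccc23)nn1` gives 30%; each of these lies below compound 1 by a gap beyond the scatter. For the measured compounds named here, the only single-point step among the measured compounds, no change at the digits printed from compound 2 to compound 3 (within the scatter), shows that exchanging the group on the double-bonded chain carbon bound to a double-bonded chain carbon left the growth inhibition unchanged. Compound 4 `COc1ccc(/C=C/C(=O)/C=C/c2ccc(OCc3cn(CCCOc4cc(=O)oc5ccccc45)nn3)c(OC)c2)cc1OC` differs from compound 1 at that same place: 3,4-dimethoxyphenyl in place of phenyl on a double-bonded chain carbon bound to a double-bonded chain carbon. Going by the values given here, no measured step tests 3,4-dimethoxyphenyl in place of phenyl with the rest of the molecule held fixed, so the expectation rests on the one exchange at this position, which moved nothing. For compound 4 the expected step is a number 3 percentage points lower from compound 1 to compound 4 (within the scatter), that is, no change beyond the scatter. Compound 4 is therefore estimated at 40%, with a range from 25% to 55%.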

Compound 4, percent growth inhibition at one concentration: 65%
For compound 4 the middle estimate is 25 percentage points below the measured one, and the stated range ends below it.
By their numbers in this assay, from the lowest: compounds 2 and 3 (each within the scatter of the next); then compound 1; then compound 4.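

In this assay, 3,4-dimethoxyphenyl in place of phenyl gives a number 22 percentage points higher from compound 1 to compound 4 (beyond the scatter), so growth inhibition at this position, on a double-bonded chain carbon bound to a double-bonded chain carbon, can shift with the group placed there. The earlier exchange at this place, thiophen-2-yl in place of 2-methoxyphenyl, gave no change at the digits printed from compound 2 to compound 3 (within the scatter), so that flat result does not hold for every exchange here, although the two steps stand on different linking chains. Nothing shown accounts for the gain.

The compounds shown leave open whether a single methoxy group, as in 4-methoxyphenyl, would carry the gain, or whether 3,4-dihydroxyphenyl or 4-aminophenyl would match it. They also leave open whether 3,4-dimethoxyphenyl would give a similar gain on the linking chain of compound 3.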